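The source may report more compounds than this note shows. Statements on the series, on what has been measured and on what is new or still open speak of the compounds shown alone.

Measured so far in an assay on CHO cells for displacement of a labelled ligand from 5-hydroxytryptamine receptor 1D (Homo sapiens); on this read-out higher numbers stand for weaker inhibition and lower numbers for stronger inhibition:
- compound 1 `NC(=O)C(c1ccccc1)N1CCN(CCCc2c[nH]c3ccc(-n4cnnc4)cc23)CC1` gives 0.2 nM
- compound 2 `c1ccc(N2CCN(CCCc3c[nH]c4ccc(-n5cnnc5)cc34)CC2)cc1` gives 1.4 nM

Among these two numbers compound 2 stands highest. Going by the values given here, its only neighbour is compound 1, from which it is separated by the step of a 7.0-fold higher number from compound 1 to compound 2 (0.85 log units; beyond the scatter), the sole measured change at the amine nitrogen of the six-membered ring with two nitrogens.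

Compound 3 `c1cnc(N2CCN(CCCc3c[nH]c4ccc(-n5cnnc5)cc34)CC2)nc1` has not yet been measured. It differs from compound 2 in one place: pyrimidin-2-yl in place of phenyl on an amine nitrogen in a ring. Among the compounds with values here, no measured step covers the exchange of one six-membered aromatic ring for another at this nitrogen; the step from compound 1 to compound 2 concerns a different exchange at the same position and says nothing direct about the present one. The ring size and the point of attachment are unchanged. Within the data shown here, with no step that bears on the change, nothing beyond the scatter is expected in this assay, in either direction. Compound 3 is therefore estimated at 2 nM, within 0.5 nM to 8 nM, an expected step of a 1.4-fold higher number from compound 2 to compound 3 (0.15 log units; within the scatter) that stays inside the scatter.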

Compound 3, half-maximal inhibitory concentration: 0.6 nM
Compound 3: the middle estimate sits 3.3-fold (0.52 log units) above what was measured; low and high end bracket the measured number.
By their numbers in this assay, from the lowest: compound 1; then compound 3; then compound 2.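

In this assay, the exchange of phenyl for pyrimidin-2-yl on the amine nitrogen gives a 2.3-fold lower number from compound 2 to compound 3 (0.37 log units; beyond the scatter) and so shows that this position responds to a change of ring atoms alone, with ring size, heavy-atom count and point of attachment unchanged. The step of a 3.0-fold higher number from compound 1 to compound 3 (0.48 log units; beyond the scatter) leaves carbamoyl(phenyl)methyl with the lowest number of the three groups at this nitrogen, and both six-membered aromatic rings on the higher side of it, so the swap to pyrimidin-2-yl recovers only part of the difference between compound 1 and compound 2. Nothing available gives a reason for either step.

Still open, going by these compounds, is whether pyridin-2-yl, with a single ring nitrogen, would fall between phenyl and pyrimidin-2-yl, which would show whether the two ring nitrogens of pyrimidin-2-yl count singly or only together. Also open, on these data alone, is how much of the low number of compound 1 depends on its carbamoyl group, a question that a carboxylic acid or a nitrile in the same place, or a plain benzyl group on this nitrogen, would address.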